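Meta Halogen Swap: Estimating Compound 3

The compounds below may be only part of what the source reports. "The series", "measured", "known", "first", "only" and "open" are said of these compounds alone.

Compound 2 `Nc1scc(-c2cccc(F)c2)c1C(=O)c1ccc(Cl)cc1` stands highest of the two numbers measured in a functional assay on CHO cells for agonist activity at adenosine receptor A1 (Homo sapiens), read by fluorescence and ERK phosphorylation, with stated times of 30 min and 1.5 h, tested at 10 uM; on this read-out lower numbers stand for a weaker effect and higher numbers for a stronger effect at the one concentration tested; in this assay compound 2 gives 90%. Among the compounds with values here, compound 1 `Nc1scc(-c2cccc(C(F)(F)F)c2)c1C(=O)c1ccc(Cl)cc1` gives 73%, and the step of a number 17 percentage points higher from compound 1 to compound 2 (beyond the scatter) is the only measured step, with fluoro in place of trifluoromethyl on an aromatic carbon. Compound 3 `Nc1scc(-c2cccc(Cl)c2)c1C(=O)c1ccc(Cl)cc1` differs from compound 2 by chloro in place of fluoro on an aromatic carbon. That single step bears on the change only loosely, since it swaps a different pair of groups at the same aromatic carbon. Compound 3 is therefore expected to lie a little below compound 2, by a step of a number 6 percentage points lower from compound 2 to compound 3 (within the scatter) that stays within the scatter. The estimate for compound 3 is 84%, ranging from 68% to 98%.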

Compound 3, a percentage reported as activity, at one concentration (the size of the read-out at that concentration, not a potency): 75%
Compound 3: the middle estimate sits 9 percentage points above what was measured, within the range that was stated.
By their numbers in this assay, from the lowest: compounds 1 and 3 (each within the scatter of the next); then compound 2.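

In this assay the 3-fluorophenyl to 3-chlorophenyl change gives a number 15 percentage points lower from compound 2 to compound 3 (beyond the scatter), so at this carbon the fluoro result does not carry over to the other halogen. Chloro and trifluoromethyl cannot be told apart here, with a number 2 percentage points higher from compound 1 to compound 3 (within the scatter), which leaves fluoro alone as the highest of the three. The data at hand offer no explanation for this. As far as these compounds go, whether an amine, a methoxy group or a nitrile on the same carbon would keep or lose the effect stays open. From the compounds shown here alone, each read-out gives the size of the effect at the one concentration tested, and how the three compounds would compare at other concentrations stays open too.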